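Cyclopentyl in Place of Cyclooctyl on Compound 2

This account rests on a few compounds, and the source may have more. Where it says the series, first, only, none or still open, it means among the compounds named here.

Two related compounds have been measured in a functional assay on MIA PaCa-2 cells (Homo sapiens) for cytotoxicity, read by fluorescence, with a stated time of 48 h; a higher number here means that more compound is needed for the effect, a lower number that less compound is needed. There, compound 1 (`CC(C)=CCC/C(C)=C/CC/C(C)=C/CSC[C@H](NC(=O)CCCCCN1CCN(C)CC1)C(=O)N1CCCC1`) gives 6000 nM, while compound 2 (`CC(C)=CCC/C(C)=C/CC/C(C)=C/CSC[C@H](NC(=O)CCCCCN1CCN(C)CC1)C(=O)NC1CCCCCCC1`) gives 2500 nM, the lower of the two numbers. Among the compounds with values here, the one measured step is a 2.4-fold lower number from compound 1 to compound 2 (0.38 log units; beyond the scatter), with cyclooctylamino in place of pyrrolidin-1-yl on a carbonyl carbon, and it is modest though beyond the scatter.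

Compound 3 (`CC(C)=CCC/C(C)=C/CC/C(C)=C/CSC[C@H](NC(=O)CCCCCN1CCN(C)CC1)C(=O)NC1CCCC1`) carries cyclopentyl in place of cyclooctyl on an amide-type nitrogen. Within the data shown here, no measured step makes this exact change, so the evidence is thin. Among the measured compounds shown here, only the step of a 2.4-fold lower number from compound 1 to compound 2 (0.38 log units; beyond the scatter) bears on it, as the one comparison that involves the cyclooctyl group of compound 2. With the eight-membered ring given up for a five-membered one, part of that modest step is expected to be lost. The step expected in this assay is a 1.6-fold higher number from compound 2 to compound 3 (0.20 log units; within the scatter), toward a higher number and smaller than the measured step. For compound 3 the estimate is 4000 nM, with an expected range of 2200 nM to 7500 nM.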

Compound 3, half-maximal effective concentration: 10900 nM
Estimate against measurement, compound 3: 2.7-fold (0.44 log units) below, outside the stated range (above it).
By their numbers in this assay, from the lowest: compound 2; then compounds 1 and 3 (each within the scatter of the next).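

In this assay, the change at the amide-type nitrogen alone moves the number beyond the scatter: a 4.4-fold higher number from compound 2 to compound 3 (0.64 log units; beyond the scatter), with cyclopentyl in place of cyclooctyl, so this position responds to the ring carried there and not only to the form of the group on the carbonyl carbon. The other new step, a 1.8-fold higher number from compound 1 to compound 3 (0.26 log units; within the scatter), leaves cyclopentylamino and pyrrolidin-1-yl indistinguishable here, so among these three compounds the lower number of compound 2 goes with the cyclooctyl group and not simply with the presence of the amide hydrogen. The data shown give no measured reason for this difference between the two rings.

The compounds shown leave open whether the number falls steadily as the ring grows or whether the eight-membered ring is a special case, a question that cyclohexyl and cycloheptyl on the same nitrogen would address. They also leave open whether a ring is needed at all, as opposed to an open chain such as octyl, and whether a larger ring such as cyclododecyl would go lower than compound 2.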